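A few compounds are considered here, and "the series" means these few. Any claim that something is new, unique, unknown or untested is made for them only; others in the source may bear on it.

Series notes, step from compound 1 to compound 4.

For the measured compounds named here, compound 1 `O=C(O)c1ccccc1-c1ccc(CCc2ncc(CC3CCCC3)[nH]2)cc1` gives 7.9 nM in an in vitro functional assay on cells for agonist activity at Bombesin receptor subtype-3 (Mus musculus), read by luminescence and calcium flux (on this read-out higher numbers stand for an effect only at larger amounts of compound and lower numbers for an effect already at smaller amounts), the second highest of the three numbers measured so far. Compound 2 `CC(C)(C)Cc1cnc(CCc2ccc(-c3ccccc3C(=O)O)cc2)[nH]1` gives 6.3 nM, and the step of a 1.3-fold lower number from compound 1 to compound 2 (0.10 log units; within the scatter) shows that a change of one saturated group for another on the saturated chain carbon leaves the read-out essentially untouched. Compound 3 `O=C(O)c1ccccc1-c1ccc(CCc2ncc(-c3ccccc3)[nH]2)cc1` gives 872 nM; here the step of a 110-fold higher number from compound 1 to compound 3 (2.04 log units; beyond the scatter) is large, and the matching step a 140-fold higher number from compound 2 to compound 3 (2.14 log units; beyond the scatter) repeats it from the other saturated partner, so placing phenyl directly on the aromatic carbon costs heavily.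

Compound 4 `Cc1ccc(Cc2cnc(CCc3ccc(-c4ccccc4C(=O)O)cc3)[nH]2)cc1` differs from compound 1 by 4-methylphenyl in place of cyclopentyl on a saturated chain carbon bound to an aromatic carbon; cut one bond further out the change reads cyclopentylmethyl to 4-methylbenzyl. The saturated chain carbon is kept, unlike in compound 3, but an aromatic ring now enters where the two measured saturated groups sat. The within-scatter step from compound 1 to compound 2 bears on the retained chain carbon, the two large steps to compound 3 on the arrival of an aromatic ring. A loss beyond the scatter is therefore expected, yet clearly smaller than a 110-fold higher number from compound 1 to compound 3 (2.04 log units; beyond the scatter). Compound 4 is expected at 25 nM, a step of a 3.2-fold higher number from compound 1 to compound 4 (0.50 log units; beyond the scatter), within 5 nM to 150 nM.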

Compound 4, half-maximal effective concentration: 162 nM
Estimate against measurement, compound 4: 6.5-fold (0.81 log units) below, outside the stated range (above it).
By their numbers in this assay, from the lowest: compounds 2 and 1 (each within the scatter of the next); then compound 4; then compound 3.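

The earlier compounds shown here showed that this place accepts two saturated groups interchangeably; compound 4 shows that this does not extend to an aromatic ring on the same saturated chain carbon, with a 21-fold higher number from compound 1 to compound 4 (1.31 log units; beyond the scatter) and a 26-fold higher number from compound 2 to compound 4 (1.41 log units; beyond the scatter) in this assay, both large. Keeping the chain carbon recovers only part of what compound 3 lost, as a 5.4-fold lower number from compound 3 to compound 4 (0.73 log units; beyond the scatter) is a modest step, so much of the loss remains with 4-methylbenzyl in place of the saturated groups and cannot be assigned to the directly attached phenyl alone. Nothing available here explains why the 4-methylphenyl change costs this much.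

On these data alone, compound 4 brings in the aromatic ring and its methyl together, so it remains open how the loss divides between them, a question that unsubstituted benzyl would address. Also open, as far as these compounds go, is whether a ring-bearing chain tolerates a basic nitrogen, as in piperidinylmethyl, or a longer chain, as in cyclopentylethyl, at this place.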